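Chloro for Fluoro on the Urea-Linked Phenyl Ring

This account rests on a few compounds, and the source may have more. Where it says the series, first, only, none or still open, it means among the compounds named here.

Of the compounds shown here, two built on a shared core have been measured in a functional assay on MDA-MB-231 cells (Homo sapiens) for cytotoxicity, read by MTT assay, with a stated time of 72 h; a lower number here means a stronger inhibitor, a higher number a weaker inhibitor. Compound 1 `CCN(CC)CCCNc1nc(-c2ccc(NC(=O)Nc3ccccc3Cl)cc2)nc2ccsc12` gives 500 nM. Compound 2 `CCN(CC)CCNc1nc(-c2ccc(NC(=O)Nc3ccccc3F)cc2)nc2ccsc12` gives 580 nM, the higher of the two numbers, yet its nearest neighbour is compound 1 and the gap between them lies within the scatter, so the two cannot be told apart on these measurements. Compound 3 `CCN(CC)CCNc1nc(-c2ccc(NC(=O)Nc3ccccc3Cl)cc2)nc2ccsc12` has not yet been measured. It differs from compound 2 in a single place: chloro in place of fluoro on an aromatic carbon. For the measured compounds named here, no measured pair shows this exchange on its own, so the expected size of the step rests only on how small the change is. Compound 3 is expected to give a number close to that of compound 2 in this assay . The expected step is a 1.3-fold lower number from compound 2 to compound 3 (0.11 log units; within the scatter), which would not reach beyond the scatter in either direction. The estimate for compound 3 is 450 nM, with a range from 200 nM to 1000 nM.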

Compound 3, half-maximal inhibitory concentration: 680 nM
Estimate against measurement, compound 3: 1.5-fold (0.18 log units) below, and the stated range covers the measured number.
By their numbers in this assay, from the lowest: compounds 1, 2 and 3 (each within the scatter of the next).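

The exchange of 2-fluorophenyl for 2-chlorophenyl now has a measured pair in this assay, with a 1.2-fold higher number from compound 2 to compound 3 (0.07 log units; within the scatter), so these two halogens cannot be told apart at this place on the ring. The chain gains a measured pair too: diethylamino in place of (diethylamino)methyl gives a 1.4-fold higher number from compound 1 to compound 3 (0.13 log units; within the scatter), so among the 2-chlorophenyl compounds these two side chains also cannot be told apart. Nothing available here offers a reason for either result.

Still open, on these data alone, is whether a different group at this place, such as methoxy or trifluoromethyl, or a plain hydrogen, would shift the number beyond the scatter. Also open, as far as these compounds go, is whether a different amine at the end of the chain, such as morpholine or piperidine in place of diethylamino, would do so.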